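The source may report more compounds than this note shows. Statements on the series, on what has been measured and on what is new or still open speak of the compounds shown alone.

Measured compounds in the series:

Compound 1 `O=C(O)c1cccc(NC(=O)C(C2CCCCC2)n2c(-c3ccc(Cl)cc3)nc3cc(F)c(F)cc32)c1` gives 14%.
Compound 2 `O=C(O)Cc1ccc(NC(=O)C(C2CCCCC2)n2c(-c3ccc(Cl)cc3)nc3cc(F)c(F)cc32)cc1` gives 14%.
Compound 3 `O=C(O)CCc1ccc(NC(=O)[C@H](C2CCCCC2)n2c(-c3ccc(Cl)cc3)nc3cc(F)c(F)cc32)c(F)c1` gives 17%.

In a functional assay for agonist activity at Bile acid receptor (Homo sapiens), read by a luciferase reporter (a lower number here means a smaller maximal response, a higher number a larger maximal response), compound 2 stands level with compound 1, and compound 3 sits within the scatter of both, so the three numbers shown are not separated by more than repeated measurement would give. Among the measured compounds shown here, the only single-site step among the measured compounds is no change at the digits printed from compound 1 to compound 2 (within the scatter), where 4-(carboxymethyl)phenyl replaces 3-carboxyphenyl on the amide-type nitrogen without moving the maximal response.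

Compound 4 `Cc1nc(NC(=O)C(C2CCCCC2)n2c(-c3ccc(Cl)cc3)nc3cc(F)c(F)cc32)sc1C(=O)O` is not yet measured. It differs from compound 2 in the same position: 5-carboxy-4-methyl-1,3-thiazol-2-yl in place of 4-(carboxymethyl)phenyl on an amide-type nitrogen. The group that leaves is a six-membered aromatic ring of carbon only; the group that enters is a five-membered aromatic ring with 2 hetero atoms, carrying the carboxy group directly on the ring and a methyl group.

For the measured compounds named here, the step from compound 1 to compound 2 is the one measured change at this attachment point and it lay within the scatter. Going by the values given here, no measured step tests a heteroaromatic ring there, so the expectation rests on that single step alone. The estimated change no change at the digits printed from compound 2 to compound 4 (within the scatter) is therefore no step beyond the scatter, in either direction. Compound 4 is expected to give about 14%, with a range from 6% to 26%.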

Compound 4, largest response reached (reported as efficacy), in percent of the reference or control that the assay uses: 10%
Estimate against measurement, compound 4: 4 percentage points above; low and high end bracket the measured number.
By their numbers in this assay, from the lowest: compounds 4, 1, 2 and 3 (each within the scatter of the next).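

In this assay, 5-carboxy-4-methyl-1,3-thiazol-2-yl on the amide-type nitrogen can now be read against both phenyl acids: the change gives a number 4 percentage points lower from compound 2 to compound 4 (within the scatter), and a number 4 percentage points lower from compound 1 to compound 4 (within the scatter). The position therefore takes a five-membered aromatic ring with 2 hetero atoms, carrying the carboxy group directly on the ring together with a methyl group, in place of a six-membered aromatic ring of carbon only, and neither step leaves the scatter of this assay. No supporting data are available to explain these numbers.

All the compounds shown carry a carboxylic acid, so the effect of a primary carboxamide or an amine in its place on the aromatic ring at this position remains open, as does that of a saturated ring such as piperidine on the amide-type nitrogen. No step shown at this position lies beyond the scatter, so it also remains open whether any group here can shift the maximal response by more than repeated measurement would give.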